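Removing the tert-butoxycarbonyl group from three peptide-like compounds

A few compounds are considered here, and "the series" means these few. Any claim that something is new, unique, unknown or untested is made for them only; others in the source may bear on it.

The measured compounds and their values in this series:
Compound 1, `CCOC(=O)/C=C/[C@H](CC(C)C)NC(=O)[C@H](CC(C)C)NC(=O)[C@H](CC(C)C)NC(=O)C1=CCCN(C(=O)OC(C)(C)C)C1`, gives > 6 h, which is a limit of the assay and not a number.
Compound 2, `CCOC(=O)/C=C/[C@H](CC(C)C)NC(=O)[C@H](CC(C)C)NC(=O)[C@H](CC(C)C)NC(=O)C1=CCCNC1`, gives > 6 h, again a limit.
Compound 3, `CCOC(=O)/C=C/[C@H](CC(C)C)NC(=O)[C@H](CO)NC(=O)[C@@H](NC(=O)C1=CCCN(C(=O)OC(C)(C)C)C1)C(C)C`, gives > 6 h, likewise a limit.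

All three values come from an ADME assay for metabolic stability, in the presence of a further agent that is not named here; on this read-out lower numbers stand for a shorter-lived compound and higher numbers for a longer-lived compound. The change from compound 1 to compound 2 is hydrogen in place of tert-butoxycarbonyl on an amine nitrogen in a ring, and the step it made is a step that the two limits leave unreadable from compound 1 to compound 2. The difference between the core of compound 1 and the core of compound 3 is not broken down here.

Compound 4, `CCOC(=O)/C=C/[C@H](CC(C)C)NC(=O)[C@H](CO)NC(=O)[C@@H](NC(=O)C1=CCCNC1)C(C)C`, has not yet been measured. It differs from compound 3 by hydrogen in place of tert-butoxycarbonyl on an amine nitrogen in a ring, the same change as that from compound 1 to compound 2, at a place described in the same words.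

Compound 4 is expected to sit at the limit as well, because of the limit of > 6 h in this assay, at which 3 of the 3 values shown sit, so the expected step is a step that the limit leaves unreadable from compound 3 to compound 4. The estimate for compound 4 in this assay is 8 h, between 4 h and 20 h, with the understanding that the assay will most likely again report only a limit.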

Compound 4, half-life: > 6 h
Compound 4 ended at the assay's limit; the forecaster's own chance of this, stated with the estimate: 80%; the middle value is on the limit's open side.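

No size can be read for the step between compound 3 and compound 4, because both stand at a limit of the assay and not at a number: the limit of > 6 h in this assay, at which 4 of the 4 values shown sit.

The compounds shown leave open how long any of the four actually lasts, and whether hydrogen in place of tert-butoxycarbonyl on an amine nitrogen in a ring changes the half-life at all.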